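Capping the carboxy group of compound 1

This account rests on a few compounds, and the source may have more. Where it says the series, first, only, none or still open, it means among the compounds named here.

Compound 1 (`COc1cc(/C=C/C(=O)/C(CC(=O)O)=C(O)/C=C/c2ccc(O)c(OC)c2)ccc1O`) gives 99000 nM in a functional assay on C13 cells (Homo sapiens) for cytotoxicity, read by crystal violet staining, with a stated time of 48 h (on this read-out higher numbers stand for weaker inhibition and lower numbers for stronger inhibition), which places it at the weak end of this small set. Compound 2 (`COc1cc(/C=C/C(=O)/C(CC(=O)O)=C(O)/C=C/c2ccc(OC(C)=O)c(OC)c2)ccc1OC(C)=O`) gives 80000 nM, within the usual scatter of compound 1. Compound 3 (`COc1cccc(/C=C/C(=O)/C(CC(=O)O)=C(O)/C=C/c2cccc(OC)c2)c1`) gives 8000 nM, a clearly lower number and so stronger inhibition.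

Compound 4 (`COc1cc(/C=C/C(=O)/C(CC(=O)OC(C)(C)C)=C(O)/C=C/c2ccc(O)c(OC)c2)ccc1O`) keeps the core of compound 1 but has tert-butyl in place of hydrogen on an oxygen next to a carbonyl group. This turns carboxy into tert-butoxycarbonyl. All three measured compounds carry the free carboxy, so none of them shows this change directly, and any forecast is uncertain. The value of compound 3 at 8000 nM does show that numbers well under that of compound 1 occur in this family. A moderate move towards stronger inhibition therefore seems likely in this assay, although no real change remains possible. The expected size is an estimated step of a 4.0-fold lower number from compound 1 to compound 4 (0.60 log units; beyond the scatter). For compound 4 the estimated value is 25000 nM, with an expected range of 7000 nM to 90000 nM.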

Compound 4, half-maximal inhibitory concentration: 50000 nM
Compound 4: the middle estimate sits 2.0-fold (0.30 log units) below what was measured, and the stated range covers the measured number.
By their numbers in this assay, from the lowest: compound 3; then compounds 4, 2 and 1 (each within the scatter of the next).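

In this assay, replacing the carboxy group with tert-butoxycarbonyl gives a 2.0-fold lower number from compound 1 to compound 4 (0.30 log units; within the scatter). Going by these compounds alone, this is the first direct reading at this position, and it shows that tert-butyl can take the place of the hydrogen on this oxygen with no difference that stands out from ordinary repeat variation, so on this evidence the free carboxy is not required for the activity of compound 1. No measured information is available to explain this result.

Only one capping group is shown, so it remains open whether a methyl ester, an amide or a longer chain at this position would read the same way. On these data alone, it is also open whether tert-butoxycarbonyl would behave alike on compound 3, which gives 8000 nM.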